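A few compounds are considered here, and "the series" means these few. Any claim that something is new, unique, unknown or untested is made for them only; others in the source may bear on it.

In a physicochemical assay for lipophilicity (a lower number here means a more polar compound, a higher number a more lipophilic compound), compound 1 `COc1ccc(C2=NO[C@]3(C2)C(=O)O[C@@H]2[C@H]3CC[C@H](C)[C@]3(O)C=CC(=O)[C@@]23C)cc1` gives 1.47 as its reading. Compound 2 `COc1ccc(C2=NO[C@]3(C2)C(=O)O[C@@H]2[C@H]3CC[C@H](C)[C@]3(O)C=CC(=O)[C@@]23C)cc1OC` gives 1.06 here, the lower of the two numbers. Compound 3 `Cc1cccc(C2=NO[C@]3(C2)C(=O)O[C@@H]2[C@H]3CC[C@H](C)[C@]3(O)C=CC(=O)[C@@]23C)c1` remains unmeasured and differs from compound 2 by 3-methylphenyl in place of 3,4-dimethoxyphenyl on a carbon with a double bond to nitrogen in one place. Going by the values given here, only one measured step bears on this: a number 0.41 log units lower from compound 1 to compound 2 (beyond the scatter) when methoxy replaced hydrogen on an aromatic carbon. Compound 3 carries no methoxy, so a larger upward change beyond the scatter is expected, an estimated a number 0.89 log units higher from compound 2 to compound 3 (beyond the scatter) overall. For compound 3 the expected value is 1.95 within an estimated range from 1.55 to 2.35 in this measurement.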

Compound 3, partition coefficient: 1.86
Estimate against measurement, compound 3: 0.09 log units above; the range from low to high includes it.
By their numbers in this assay, from the lowest: compound 2; then compound 1; then compound 3.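

In this assay 3-methylphenyl in place of 3,4-dimethoxyphenyl gives a number 0.80 log units higher from compound 2 to compound 3 (beyond the scatter) and 3-methylphenyl in place of 4-methoxyphenyl gives a number 0.39 log units higher from compound 1 to compound 3 (beyond the scatter) at the same carbon with a double bond to nitrogen. This position therefore moves the reading upward as well as downward, and compound 3 stands highest of the three, with both steps beyond the scatter. Nothing available explains these differences. The compounds shown leave open how an amine, a carboxylic acid or a longer chain on the aromatic ring would read in this assay at this position.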